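The compounds below may be only part of what the source reports. "The series", "measured", "known", "first", "only" and "open" are said of these compounds alone.

Measured so far in an ADME assay on Huh-7 cells (Homo sapiens) for cytotoxicity; on this read-out lower numbers stand for higher toxicity in this test and higher numbers for lower toxicity in this test:
- compound 1 `Cc1ccccc1-c1nn(-c2ccc(F)cc2F)cc1CNCCCCO`: > 20000 nM
- compound 2 `CCCN1CCC(CNCc2cn(-c3ccc(F)cc3F)nc2-c2ccccc2C)CC1`: > 20000 nM
- compound 3 `Cc1ccccc1-c1nn(-c2ccc(F)cc2F)cc1CNCCCN1CCN(C)CC1`: > 20000 nM

Each of these three values is a limit of the assay, not a number. For compound 3 only such a limit is known, and the two further values in the series are limits as well, so compound 3 cannot be placed above or below either neighbour; all three sit together at the limit of > 20000 nM in this assay, at which 3 of the 3 values shown sit. With every value at that limit, the steps a step that the two limits leave unreadable from compound 1 to compound 2, a step that the two limits leave unreadable from compound 1 to compound 3 and a step that the two limits leave unreadable from compound 2 to compound 3 are not readable in size or direction.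

Compound 4 `CCCCCNCc1cn(-c2ccc(F)cc2F)nc1-c1ccccc1C` differs from compound 3 by ethyl in place of 4-methylpiperazin-1-yl on a saturated chain carbon, three bonds along the chain from an amine nitrogen. For the measured compounds named here, no measured step bears readably on this change: the three known steps are all bracketed by the same limit and give no size to carry over. What the series does show is that neither the 3-hydroxypropyl, the 1-propylpiperidin-4-yl nor the 4-methylpiperazin-1-yl variant reached a readable value, so a shorter plain pentyl chain is not expected to behave otherwise. Compound 4 is therefore expected to register again at the limit, with an estimate of 30000 nM and a range from 12000 nM to 100000 nM. Going by the values given here, the estimated step is a step that the limit leaves unreadable from compound 3 to compound 4, that is, no step expected beyond the scatter.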

Compound 4, half-maximal cytotoxic concentration: 17000 nM
The estimate for compound 4 lay 1.8-fold (0.25 log units) above the measured number, and the stated range covers the measured number.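

In this assay, for the compounds shown here, compound 4, which ends in a plain pentyl chain, is the first to give a number rather than a limit: 17000 nM. Ethyl in place of 4-methylpiperazin-1-yl gives an at least 1.1-fold lower number from compound 3 to compound 4 (0.07 log units; that floor lies within the scatter), butyl in place of 1-propylpiperidin-4-yl gives an at least 1.1-fold lower number from compound 2 to compound 4 (0.07 log units; that floor lies within the scatter), and methyl in place of hydroxy gives an at least 1.1-fold lower number from compound 1 to compound 4 (0.07 log units; that floor lies within the scatter). A chain with no ring and no hydrogen-bond acceptor therefore brings a readable value into the series, but no real fall is established, since each step is only a floor within the scatter and compound 1, compound 2 and compound 3 remain at a limit: the limit of > 20000 nM in this assay, at which 3 of the 4 values shown sit.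

On these data alone, it remains open whether a longer chain, such as octyl, would lower the number beyond the scatter, or whether a carboxylic acid at the chain end would return it to the limit. As far as these compounds go, the true distance between compound 4 and the other three compounds also remains open, as their values are limits and give no size for any of these changes.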